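A few compounds are considered here, and "the series" means these few. Any claim that something is new, unique, unknown or untested is made for them only; others in the source may bear on it.

Measured compounds and their solubility readings:
compound 1, `CN1CCC(C(=O)N2Cc3c(NC(=O)c4ccc(Cl)cc4)n[nH]c3C2(C)C)CC1`: > 225000 nM
compound 2, `CN1CCC(C(=O)Nc2n[nH]c3c2CN(C(=O)C(C)(C)C)C3(C)C)CC1`: > 225000 nM
compound 3, `CN1CCN(C(=O)N2Cc3c(NC(=O)c4ccc(F)cc4)n[nH]c3C2(C)C)CC1`: > 225000 nM

In a physicochemical assay for solubility, at pH 7 (a higher number here means a more soluble compound, a lower number a less soluble compound), compound 1 gives > 225000 nM, and this is a limit of the assay rather than a measured number. All three measured compounds sit at the limit of > 225000 nM in this assay, at which 3 of the 3 values shown sit, so these figures separate none of them. Compound 4, `CN1CCC(C(=O)N2Cc3c(NC(=O)c4ccccc4)n[nH]c3C2(C)C)CC1`, differs from compound 1 in one place: hydrogen in place of chloro on an aromatic carbon. Within the data shown here, no pair of measured compounds differs in a single place, so no measured step guides this change. With every measured value resting at the same limit, compound 4 is expected to move by no more than the usual scatter, an expected step of a number no higher from compound 1 to compound 4 (the limit leaves the size open). For compound 4 the solubility is estimated at 225000 nM, with a range from 100000 nM to 500000 nM.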

Compound 4, solubility: > 225000 nM
Compound 4 was reported as a limit; the forecaster's own chance of this, stated with the estimate: 75%; the middle value sits exactly at the limit.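

Compound 1 and compound 4 both give only a limit in this assay and no step between them can be read: the limit of > 225000 nM in this assay, at which 4 of the 4 values shown sit.
The compounds shown leave open how far any of these solubilities lies beyond that limit, and whether swapping chloro for hydrogen changes solubility at all.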